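The source may hold more compounds than are shown below. What is called first, only, known or untested is meant among the compounds shown, and "the series" means these compounds.

In a functional assay on SGC-7901 cells (Homo sapiens) for inhibition, read by MTT assay, with a stated time of 24 h (a higher number here means a weaker inhibitor, a lower number a stronger inhibitor), three compounds with a shared core have been measured: compound 1 (`CC1(C)[C@H]2CC[C@]1(C)N(Cc1cn(-c3cccc(F)c3)nn1)C(=O)C2`) gives 530 nM, compound 2 (`CC1(C)[C@H]2CC[C@]1(C)N(Cc1cn(-c3ccc(C#N)cc3)nn1)C(=O)C2`) gives 500 nM, and compound 3 (`CC1(C)[C@H]2CC[C@]1(C)N(Cc1cn(-c3ccccc3F)nn1)C(=O)C2`) gives 300 nM. Compound 3 thus stands within the scatter of both others. Compound 4 (`CC1(C)[C@H]2CC[C@]1(C)N(Cc1cn(-c3cccc(Cl)c3)nn1)C(=O)C2`) has 3-chlorophenyl in place of 2-fluorophenyl on an aromatic nitrogen. Three measured steps change this same group: a 1.1-fold lower number from compound 1 to compound 2 (0.03 log units; within the scatter), a 1.8-fold lower number from compound 1 to compound 3 (0.25 log units; within the scatter) and a 1.7-fold lower number from compound 2 to compound 3 (0.22 log units; within the scatter). With all three inside the scatter, and compound 1, which carries 3-fluorophenyl, at 530 nM, no step beyond the scatter is expected in this assay. The expected change is a 1.4-fold higher number from compound 3 to compound 4 (0.15 log units; within the scatter). For compound 4 the estimated value is 420 nM, with an expected range from 180 nM to 1000 nM.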

Compound 4, half-maximal inhibitory concentration: 510 nM
For compound 4 the middle estimate is 1.2-fold (0.08 log units) below the measured one; the measured number falls inside the stated range.
By their numbers in this assay, from the lowest: compounds 3, 2, 4 and 1 (each within the scatter of the next).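

In this assay, among the compounds shown here, chloro in place of fluoro on an aromatic carbon gives a 1.0-fold lower number from compound 1 to compound 4 (0.02 log units; within the scatter) and so adds the first change of the halogen alone, at a place where the phenyl group otherwise stays the same. Set against the other two aryl groups, 3-chlorophenyl gives a 1.7-fold higher number from compound 3 to compound 4 (0.23 log units; within the scatter) and a 1.0-fold higher number from compound 2 to compound 4 (0.01 log units; within the scatter), so this position has still shown no step beyond the scatter. No evidence is available that bears on these results. Every phenyl group shown carries a single halogen or nitrile. From the compounds shown here alone, what an amine or a carboxylic acid on that phenyl, or a longer alkyl chain in its place, would give in this assay remains open.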